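Trimming One Methoxy Group from a Cell-Toxicity Lead

This account rests on a few compounds, and the source may have more. Where it says the series, first, only, none or still open, it means among the compounds named here.

Compound 2 `COc1cc(CNc2nc3cc(N)cc(N)c3nc2-c2ccccc2)cc(OC)c1OC` gives 29500 nM in a functional assay on UACC-62 cells (Homo sapiens) for inhibition, read by sulforhodamine B assay, with a stated time of 48 h (on this read-out higher numbers stand for lower toxicity in this test and lower numbers for higher toxicity in this test), the lowest number of the two shown. Compound 1 `Nc1cc(N)c2nc(-c3ccccc3)c(NCc3ccc(Cl)c(Cl)c3)nc2c1` gives 67600 nM in this assay, a gap beyond the usual scatter. Compound 3 `COc1ccc(CNc2nc3cc(N)cc(N)c3nc2-c2ccccc2)cc1OC` differs from compound 2 in one place: hydrogen in place of methoxy on an aromatic carbon. Within the data shown here, no measured pair isolates this change, so its effect cannot be read from the data. The step of a 1.3-fold higher number from compound 2 to compound 3 (0.11 log units; within the scatter) is expected to stay within the scatter, leaning toward a slightly higher number. Compound 3 is estimated at 38000 nM, most likely between 15000 nM and 90000 nM.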

Compound 3, concentration lethal to 50% of the cells: 53700 nM
The estimate for compound 3 lay 1.4-fold (0.15 log units) below the measured number; measured number inside the range.
By their numbers in this assay, from the lowest: compounds 2, 3 and 1 (each within the scatter of the next, the first and the last beyond it).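

Hydrogen in place of methoxy on this aromatic carbon gives a 1.8-fold higher number from compound 2 to compound 3 (0.26 log units; within the scatter) in this assay and so leaves the read-out within the scatter at this position. With hydrogen there, 3,4-dimethoxyphenyl in place of 3,4-dichlorophenyl gives a 1.3-fold lower number from compound 1 to compound 3 (0.10 log units; within the scatter) and also stays within the scatter in this assay. Nothing measured here gives a reason for either result. Still open, from the compounds shown here alone, is whether an amine, a carboxylic acid or a longer chain on this aromatic carbon would move the number beyond the scatter.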